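The source may report more compounds than this note shows. Statements on the series, on what has been measured and on what is new or still open speak of the compounds shown alone.

Three compounds have results in an ADME assay on BaF3 cells (Mus musculus) for cytotoxicity; on this read-out lower numbers stand for an effect already at smaller amounts and higher numbers for an effect only at larger amounts of compound. Compound 1 `CN1CCN(C(=O)c2cc3c(Nc4ccc(OC(F)(F)F)cc4)ncnc3s2)CC1` gives 2690 nM. Compound 2 `FC(F)(F)Oc1ccc(Nc2cc(-n3ccnc3)ncn2)cc1` gives a result at the assay limit, > 10000 nM, which is a limit rather than a number. Compound 3 `FC(F)(F)Oc1ccc(Nc2ncnc3nn(C4CCCCC4)cc23)cc1` likewise stops at its own limit of > 10000 nM. Compound 2 thus stands at the limit of > 10000 nM in this assay, at which 2 of the 3 values shown sit, so nothing more exact is known for it. Compound 4 `FC(F)(F)Oc1ccc(Nc2cc(-c3ccc4[nH]ccc4c3)ncn2)cc1` has not yet been measured; it differs from compound 2 by 1H-indol-5-yl in place of 1H-imidazol-1-yl on an aromatic carbon. Going by the values given here, no measured pair shows a change of this kind, so the size of the step cannot be read off; a modest move toward lower values in this assay is expected, one that could still sit within the scatter. For compound 4 the estimated value is 6000 nM, with a range from 2000 nM to 20000 nM. The expected step is an at least 1.6-fold lower number from compound 2 to compound 4 (0.22 log units; that floor lies within the scatter).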

Compound 4, half-maximal effective concentration: > 10000 nM
Compound 4 gave a limit, no number; the forecaster's own chance of this, stated with the estimate: 55%; at least 1.6-fold (0.22 log units) between middle value and limit.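

Compound 2 and compound 4 both end at a limit rather than a number, so no step between them can be read: the limit of > 10000 nM in this assay, at which 3 of the 4 values shown sit.

As far as these compounds go, whether 1H-indol-5-yl in place of 1H-imidazol-1-yl changes this read-out at all remains open.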